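Sulfonyl aryl exchange in a sulfonamide acetamide series

This account rests on a few compounds, and the source may have more. Where it says the series, first, only, none or still open, it means among the compounds named here.

Compound 1 `CCN(CC)C(=O)CN(c1ccc(C)cc1)S(=O)(=O)c1cccc(Cl)c1` is the reference point here. In a functional assay on CHO cells for inhibition of Orexin/Hypocretin receptor type 1 (Homo sapiens), read by FLIPR and calcium flux (on this read-out higher numbers stand for weaker inhibition and lower numbers for stronger inhibition), compound 1 gives > 10000 nM, which is a limit of the assay and not a number, so compound 1 stands only at the weak end of what has been measured. The other measured compound, compound 2 `CCN(CC)C(=O)CN(c1cc(C(C)C)ccc1Cl)S(=O)(=O)c1ccc(OC)c(OC)c1`, differs from compound 1 in both aryl groups at once; in this assay compound 2 gives 888 nM. Going by the values given here, no two measured compounds differ in a single place, so no measured step fixes the weight of any one exchange. Compound 3 `CCN(CC)C(=O)CN(c1ccc(C)cc1)S(=O)(=O)c1ccc(OC)cc1` carries 4-methoxyphenyl in place of 3-chlorophenyl on a sulfonyl sulfur. Among the compounds with values here, the only evidence on compound 1 is the limit (the limit of > 10000 nM in this assay, at which 1 of the 2 values shown sits), which offers no anchor for the size of this exchange. For compound 3 a small gain in this assay is expected, not clearly beyond the scatter, with a fair chance that the assay again reports only a limit. Compound 3 is expected to give 8000 nM in this assay, within 2000 nM to 30000 nM. The estimated step is an at least 1.2-fold lower number from compound 1 to compound 3 (0.09 log units; that floor lies within the scatter).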

Compound 3, half-maximal inhibitory concentration: > 10000 nM
Compound 3: a limit, no number (the forecaster's own chance of this, stated with the estimate: 55%); middle value at least 1.2-fold (0.09 log units) from the limit.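

Going by these compounds alone, compound 1 and compound 3 both return only a limit of the assay, not a number, in this assay, so no step between them can be read: the limit of > 10000 nM in this assay, at which 2 of the 3 values shown sit.

The compounds shown leave open the size of the exchange of 3-chlorophenyl for 4-methoxyphenyl on a sulfonyl sulfur, and even its direction.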